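Swapping Methyl for Chloro on the Benzyl Ring

The compounds below may be only part of what the source reports. "The series", "measured", "known", "first", "only" and "open" are said of these compounds alone.

Measured compounds:
Compound 1, `CC(C)(C)c1cc(C(=O)NCCC2CCN(Cc3ccccc3)CC2)cc(C(C)(C)C)c1O`: 89200 nM
Compound 2, `CC(C)(C)c1cc(CCC(=O)NC2CCN(Cc3ccccc3)CC2)cc(C(C)(C)C)c1O`: 70400 nM
Compound 3, `Cc1ccccc1CN1CCC(CCNC(=O)/C=C/c2cc(C(C)(C)C)c(O)c(C(C)(C)C)c2)CC1`: 7200 nM

All three compounds were tested in an assay on isolated protein for inhibition of Amine oxidase [flavin-containing] B (Homo sapiens), read by fluorescence, with stated times of 15 min and 20 min; a higher number here means a weaker inhibitor, a lower number a stronger inhibitor. Compound 3 stands at the lowest number of the three, and its distance to both compound 2 and compound 1 lies beyond the usual scatter of this assay, so compound 3 is the strongest inhibitor among the measured set.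

Compound 4, `CC(C)(C)c1cc(/C=C/C(=O)NCCC2CCN(Cc3ccccc3Cl)CC2)cc(C(C)(C)C)c1O`, is the next compound to be measured. It differs from compound 3 in a single place: chloro in place of methyl on an aromatic carbon, ortho to a large group. Among the measured compounds no pair differs in exactly this way, so there is no measured step of this kind to lean on. A one-atom swap of this sort, with nothing gained or lost in ring count, hydrogen-bond donors or acceptors, is expected to move the number little, if at all: the step from compound 3 to compound 4 is estimated as a 1.0-fold lower number from compound 3 to compound 4 (0.01 log units; within the scatter), not clearly beyond the scatter in either direction.

Compound 4 is therefore expected to give about 7000 nM in this assay, with a likely range from 2500 nM to 20000 nM.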

Compound 4, half-maximal inhibitory concentration: 9800 nM
Estimate against measurement, compound 4: 1.4-fold (0.15 log units) below; low and high end bracket the measured number.
By their numbers in this assay, from the lowest: compounds 3 and 4 (each within the scatter of the next); then compounds 2 and 1 (each within the scatter of the next).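

In this assay, the change from 2-methylbenzyl to 2-chlorobenzyl gives a 1.4-fold higher number from compound 3 to compound 4 (0.13 log units; within the scatter), so this place on the ring takes either group with no difference that can be told apart from the ordinary spread of repeated measurements. Going by these compounds alone, this is the first direct reading of a change on this ring. Compounds 1 and 2 do not pair with either compound through a single change. The reading shows that methyl and chloro, each a single heavy atom with no hydrogen-bond donors or acceptors, are interchangeable here as far as this measurement can tell. Nothing on hand explains why the two groups read alike, and no outside measurement bears on this result.

Going by these compounds, how a plain benzyl group would read on the chain of compound 3 remains open, so it cannot yet be said whether either methyl or chloro contributes anything at this place. Also open, on these data alone, is whether a larger or differently built group here, such as methoxy, nitrile or an amine, would give a step beyond the scatter.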